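Swapping tert-butyl for bromo in a weakly active series

A few compounds are considered here, and "the series" means these few. Any claim that something is new, unique, unknown or untested is made for them only; others in the source may bear on it.

Three related compounds have been tested in a functional assay on MCF7 cells (Homo sapiens) for antiproliferative activity, read by MTT assay, with a stated time of 72 h; a lower number here means a stronger inhibitor, a higher number a weaker inhibitor. Compound 1 `C=CC/N=C1\S/C(=C\c2ccc(OC)cc2)C(=O)N1C` gives > 100000 nM, which is a limit of the assay and not a number. Compound 2 `COc1ccc(/C=C2/CN(C)/C(=N/c3ccc(C(C)(C)C)cc3)S2)cc1` gives 28700 nM, the higher of the two actual numbers. Compound 3 `FC(F)(F)c1cc(/N=C2/NC/C(=C/c3ccccc3)S2)cc(C(F)(F)F)c1` gives 13500 nM, a lower number, and the gap to compound 2 lies just beyond the usual scatter. All three therefore sit at the weak end of what this kind of test can report.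

The next compound to be tested is compound 4 `COc1ccc(/C=C2/CN(C)/C(=N/c3ccc(Br)cc3)S2)cc1`. It keeps the shared core of compound 2 and carries bromo in place of tert-butyl on an aromatic carbon. The group changes, but its place on the ring does not.

Within the data shown here, no two measured compounds here differ in one place only, so nothing shows directly what this swap does. The best anchor is compound 2 at 28700 nM, and the expectation must stay broad. No change beyond the scatter is expected, in either direction, and the estimated step is a 1.1-fold lower number from compound 2 to compound 4 (0.06 log units; within the scatter). The expected value for compound 4 is 25000 nM, with an estimated range from 8000 nM to 80000 nM.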

Compound 4, half-maximal inhibitory concentration: 7400 nM
Compound 4: middle estimate off by 3.4-fold (0.53 log units), on the high side; the measured number lies below the stated range.
By their numbers in this assay, from the lowest: compounds 4 and 3 (each within the scatter of the next); then compound 2. At a limit, above all of these: compound 1.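

In this assay, among these compounds, this is the first direct reading of what the group on this aromatic carbon, para to a large group, can do: putting bromo in place of tert-butyl gives a 3.9-fold lower number from compound 2 to compound 4 (0.59 log units; beyond the scatter). The position is therefore not indifferent to what it carries, since this one change, with the shared core left as it was, moves the number beyond the usual scatter, though only by a modest step, and it replaces a group of 4 heavy atoms with a group of 1 heavy atom. Compound 1 alone stands at a limit, which is not a number, so this step is read between two actual numbers: the limit of > 100000 nM in this assay, at which 1 of the 4 values shown sits.

Two groups at one position cannot show whether the gain comes from losing tert-butyl or from gaining bromo, and the step gives no reason for the difference. Going by these compounds, how a chloro, a methoxy group or an amine would read at the same place remains open, and so does whether any group there could move the series far from the weak end of this test.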